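Cyano in place of methyl on compound 3

A few compounds are considered here, and "the series" means these few. Any claim that something is new, unique, unknown or untested is made for them only; others in the source may bear on it.

In a functional assay on NALM-6 cells (Homo sapiens) for cytotoxicity, read by luminescence and CellTiter-Glo, with a stated time of 3 days (on this read-out higher numbers stand for weaker inhibition and lower numbers for stronger inhibition), compound 1 (`O=C(Nc1ccc(C(F)(F)F)cc1)c1cc(F)ccc1O`) gives 2090 nM and stands higher than the other two measured compounds. Compound 2 (`N#Cc1ccc(NC(=O)c2ccc3cccnc3c2O)c(F)c1`) gives 370 nM and compound 3 (`Cc1cc(C#N)ccc1NC(=O)c1ccc2cccnc2c1O`) gives 230 nM on the same read-out, so compound 3 sits level with compound 2 at the low end of these numbers. Compared with compound 3, compound 4 (`N#Cc1ccc(NC(=O)c2ccc3cccnc3c2O)c(C#N)c1`) has cyano in place of methyl on an aromatic carbon and nothing else changed. Within the data shown here, the one measured swap on this carbon (a 1.6-fold lower number from compound 2 to compound 3 (0.21 log units; within the scatter)) stayed within the scatter, so in this assay no step beyond the scatter is expected here either. The estimated change is small (a 1.3-fold higher number from compound 3 to compound 4 (0.12 log units; within the scatter)) in size. For compound 4 the expected value is 300 nM within an estimated range from 100 nM to 900 nM overall.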

Compound 4, half-maximal inhibitory concentration: 350 nM
The estimate for compound 4 lay 1.2-fold (0.07 log units) below the measured number; the range from low to high includes it.
By their numbers in this assay, from the lowest: compounds 3, 4 and 2 (each within the scatter of the next); then compound 1.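

In this assay, the carbon ortho to a large group now carries three different groups, and the numbers stay close. Cyano, with one more heavy atom and one more hydrogen-bond acceptor than methyl, gives a 1.5-fold higher number from compound 3 to compound 4 (0.18 log units; within the scatter), and against fluoro it gives a 1.1-fold lower number from compound 2 to compound 4 (0.02 log units; within the scatter), so neither step leaves the scatter. No separate measurement bears on why these numbers stay so close.

On these data alone, whether an amine, a carboxylic acid or a longer chain on this carbon would move the number beyond the scatter remains open. So does whether these swaps would behave alike on the core of compound 1.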